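Swapping the pyridinyl group of compound 3

The source may hold more compounds than are shown below. What is called first, only, known or untested is meant among the compounds shown, and "the series" means these compounds.

Compound 1 `COc1ccnc(Nc2cc3[nH]c(-c4cccc(C(F)(F)F)c4)nc3cn2)c1` gives < 5000 nM as a limit
Compound 2 `FC(F)(F)c1cccc(-c2nc3cnc(Nc4ccncn4)cc3[nH]2)c1` gives < 5000 nM as a limit
Compound 3 `Fc1cnc(Nc2cc3[nH]c(-c4cccc(C(F)(F)F)c4)nc3cn2)c(F)c1` gives < 5000 nM as a limit

All three were tested in a physicochemical assay for solubility, using the shake flask method, in phosphate buffer, measured as kinetic solubility, with a stated time of 20 h, at pH 6.5 (a lower number here means a less soluble compound, a higher number a more soluble compound), and none gave an exact number. Compound 3 stands at the limit of < 5000 nM in this assay, at which 3 of the 3 values shown sit, and so has no exact place of its own. Compound 4 `FC(F)(F)c1ccc(Nc2cc3[nH]c(-c4cccc(C(F)(F)F)c4)nc3cn2)nc1` differs from it by 5-(trifluoromethyl)pyridin-2-yl in place of 3,5-difluoropyridin-2-yl on a nitrogen on an aromatic ring with 5-(trifluoromethyl)pyridin-2-yl in place of 3,5-difluoropyridin-2-yl on a nitrogen on an aromatic ring. Three measured changes at this same place bear on it: a step that the two limits leave unreadable from compound 1 to compound 2 then a step that the two limits leave unreadable from compound 1 to compound 3 and also a step that the two limits leave unreadable from compound 2 to compound 3 and none of them has a size to carry over. So no step beyond the scatter and no direction can be expected in this assay for this swap. The expected step is a step that the limit leaves unreadable from compound 3 to compound 4 as an estimate only. Compound 4 is expected near 3000 nM with an estimated range from 1000 nM to 6000 nM and a limit is the likeliest report.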

Compound 4, solubility: < 5000 nM
Compound 4 ended at the assay's limit; the forecaster's own chance of this, stated with the estimate: 85%; the middle value lies beyond the limit too.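

Compound 4 gives < 5000 nM, which is a limit, so no step can be read from compound 1, compound 2 or compound 3 to compound 4: the limit of < 5000 nM in this assay, at which 4 of the 4 values shown sit. On these data alone, whether swapping the group on that nitrogen changes the solubility at all, and in which direction, stays open.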